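A few compounds are considered here, and "the series" means these few. Any claim that something is new, unique, unknown or untested is made for them only; others in the source may bear on it.

Measured in a functional assay on U-251 cells (Homo sapiens) for cytotoxicity; on this read-out higher numbers stand for weaker inhibition of growth and lower numbers for stronger inhibition of growth:
- compound 1 `COc1ccc(C2=C(c3cc(OC)c(OC)c(OC)c3)CC3CCCN3C2=O)cc1O`: > 100000 nM (a limit)
- compound 2 `COc1ccc(C2=C(c3ccc(SC)cc3)CC3CCCN3C2=O)cc1OC(=O)CNC(=O)OC(C)(C)C`: 6000 nM
- compound 3 `COc1ccc(C2=C(c3ccc(SC)cc3)CC3CCCN3C2=O)cc1C`: 90 nM

Of the two true numbers in this assay, compound 3 at 90 nM is the lower, and compound 2 stands at 6000 nM on the other side of a gap well beyond the scatter. The value of compound 1 is a limit and gives no number to rank against.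

The next compound is compound 4 `CSc1ccc(C2=C(c3ccc(F)c(C)c3)C(=O)N3CCCC3C2)cc1`, not yet measured. The change from compound 3 is fluoro in place of methoxy on an aromatic carbon, ortho to a methyl group and para to a large group.

Within the data shown here, no measured step exchanges this methoxy group. Among the measured compounds shown here, the only step available is a 67-fold lower number from compound 2 to compound 3 (1.82 log units; beyond the scatter), a large one, made at another substituent on the same aromatic ring. It shows that this ring can carry a big shift in the read-out, but it was a far larger exchange than the one here. For the measured compounds named here, a smaller move is therefore expected, more likely towards a higher number given that compound 3 already sits at 90 nM and only one favourable value is known. The expected change is a 3.3-fold higher number from compound 3 to compound 4 (0.52 log units; beyond the scatter), with wide uncertainty.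

For compound 4 the estimated value is 300 nM, with an expected range from 60 nM to 2000 nM.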

Compound 4, concentration for 50% growth inhibition: 200 nM
Compound 4: middle estimate off by 1.5-fold (0.18 log units), on the high side, and the stated range covers the measured number.
By their numbers in this assay, from the lowest: compound 3; then compound 4; then compound 2. At a limit, above all of these: compound 1.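

Working notes on the methoxy position, on the aromatic carbon ortho to a methyl group and para to a large group: in this assay, the exchange of methoxy for fluoro gives a 2.2-fold higher number from compound 3 to compound 4 (0.35 log units; beyond the scatter), the first direct reading at this position. The step is modest and lies beyond the scatter, so the methoxy group is favoured over fluoro here, but growth inhibition does not depend on it to anything like the extent seen at the other substituent on this ring, where the step reads a 67-fold lower number from compound 2 to compound 3 (1.82 log units; beyond the scatter). Nothing measured on these compounds gives a reason for the step from methoxy to fluoro, and the one available limit does not bear on it.

From the compounds shown here alone, a single exchange gives no trend for this position, so it remains open how an amine, a carboxylic acid, a hydroxyl group or a longer alkoxy chain would read here, and whether anything larger than methoxy would be tolerated. Going by these compounds, it also remains open whether the same modest shift would hold without the methyl group ortho to this position, since both compounds in this step carry it.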